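This account rests on a few compounds, and the source may have more. Where it says the series, first, only, none or still open, it means among the compounds named here.

Measured compounds:
compound 1, `CCNC(=O)c1noc(-c2cc(C(C)C)c(O)cc2O)c1-c1cc(CO)no1`, giving 5 nM in a functional assay on A2780 cells (Homo sapiens) for inhibition; a lower number here means a stronger inhibitor, a higher number a weaker inhibitor;
compound 2, `CCNC(=O)c1noc(-c2cc(C(C)C)c(O)cc2O)c1-c1cc(CNC)no1`, whose entry in this assay reads "not determined" (no result reported), so no number was reported for it.

For the measured compounds named here, compound 1 therefore stands alone on the numbers: its half-maximal inhibitory concentration is the single value available in this assay, and compound 2 adds a second structure without a number to set beside it. Going by the values given here, no pair of measured compounds differing in a single place is available, so no measured step can be quoted.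

Compound 3, `CCNC(=O)c1noc(-c2cc(C(C)C)c(O)cc2O)c1-c1cnn(C(C)C)c1`, is the next compound to be measured in this assay. It differs from compound 1 in one place: 1-isopropyl-1H-pyrazol-4-yl in place of 3-(hydroxymethyl)-1,2-oxazol-5-yl on an aromatic carbon. The group that leaves carries a hydrogen-bond donor and the group that enters carries none, with both groups being five-membered aromatic rings with two hetero atoms.

Among the compounds with values here, with no measured step to lean on, a moderate loss is expected, somewhat beyond the scatter, from compound 1 to compound 3, a 3.0-fold higher number from compound 1 to compound 3 (0.48 log units; beyond the scatter). Compound 3 is thus estimated at 15 nM, within a range of 4 nM to 60 nM.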

Compound 3, half-maximal inhibitory concentration: 21 nM
Estimate against measurement, compound 3: 1.4-fold (0.15 log units) below, and the stated range covers the measured number.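

In this assay, for the compounds shown here, 1-isopropyl-1H-pyrazol-4-yl in place of 3-(hydroxymethyl)-1,2-oxazol-5-yl gives a 4.2-fold higher number from compound 1 to compound 3 (0.62 log units; beyond the scatter) and provides the first measured step at this position, showing that this aromatic carbon accepts a different five-membered aromatic ring at a modest cost, with compound 3 still at 21 nM in this series. The change alters the ring, removes the hydrogen-bond donor and adds an isopropyl group all at once, so the step cannot be divided among these differences. No measurement shown accounts for the step.

On these data alone, it remains open whether a methyl or a carboxylic acid in place of the hydroxymethyl group on the same ring would move the number. As far as these compounds go, it is also open how a methyl in place of the isopropyl group on the pyrazolyl ring would compare with compound 3.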